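Thiophen-3-yl in place of thiophen-2-yl: working notes

The source may report more compounds than this note shows. Statements on the series, on what has been measured and on what is new or still open speak of the compounds shown alone.

Measured so far:
compound 1, `Cc1nc(N)c2c(-c3cccs3)cn([C@@H]3O[C@H](CO)[C@@H](O)[C@H]3O)c2n1`: > 20000 nM
compound 2, `O=c1[nH]cnc2c1c(-c1cc3ccccc3o1)cn2[C@@H]1O[C@H](CO)[C@@H](O)[C@H]1O`: > 20000 nM

In a functional assay on HeLa S3 cells (Homo sapiens) for antiproliferative activity, read by XTT assay, with a stated time of 72 h (on this read-out higher numbers stand for weaker inhibition and lower numbers for stronger inhibition), compound 1 gives > 20000 nM, which is a limit of the assay and not a number. In this assay compound 2 likewise gives only the limit > 20000 nM. Compound 1 therefore stands at the limit, and so does the other value shown, (the limit of > 20000 nM in this assay, at which 2 of the 2 values shown sit). Going by the values given here, no step between two measured compounds is available, so nothing about the size of any structural change in this assay can be read from these two compounds.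

Compound 3, `Cc1nc(N)c2c(-c3ccsc3)cn([C@@H]3O[C@H](CO)[C@@H](O)[C@H]3O)c2n1`, differs from compound 1 in one place: thiophen-3-yl in place of thiophen-2-yl on an aromatic carbon. Because compound 1 rests at the limit > 20000 nM in this assay, the step that the limit leaves unreadable from compound 1 to compound 3 is expected to be none beyond the scatter, and compound 3 is expected most likely to come back as a limit as well. For compound 3 the estimate in this assay is 25000 nM, with a range from 8000 nM to 80000 nM.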

Compound 3, half-maximal inhibitory concentration: > 20000 nM
Compound 3: only a limit was reported; the forecaster's own chance of this, stated with the estimate: 80%; the middle value is on the limit's open side.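

In this assay, compound 1 and compound 3 both return only limits of the assay, so no step between them can be read: the limit of > 20000 nM in this assay, at which 3 of the 3 values shown sit.

The compounds shown leave open whether thiophen-3-yl and thiophen-2-yl differ at all here, and which change to the shared core would give a readable value.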